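Removing the Amino Group from a Benzyl-Substituted Purine

This account rests on a few compounds, and the source may have more. Where it says the series, first, only, none or still open, it means among the compounds named here.

Measured compounds:
compound 1, `ClCc1cccc(Cn2cnc3c(Cl)nc(Cl)nc32)c1`, 6450 nM
compound 2, `Nc1nc(Cl)c2ncn(Cc3ccccc3CCl)c2n1`, 24600 nM
compound 3, `ClCc1ccccc1Cn1cnc2ncnc(Cl)c21`, > 100000 nM

Three compounds were tested in a functional assay on MCF7 cells (Homo sapiens) for cytotoxicity, read by sulforhodamine B assay, with a stated time of 48 h; on this read-out lower numbers stand for stronger inhibition of growth and higher numbers for weaker inhibition of growth. Compound 1 gives 6450 nM. Compound 2 gives 24600 nM, the highest of the two plain numbers; its nearest neighbour is compound 1, whose number is lower by a gap beyond the usual scatter. For compound 3 this assay reports only a limit, > 100000 nM, not a number (the limit of > 100000 nM in this assay, at which 1 of the 3 values shown sits).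

Compound 4, `ClCc1ccccc1Cn1cnc2c(Cl)ncnc21`, has not yet been measured. It differs from compound 2 in one place: hydrogen in place of amino on an aromatic carbon. Going by the values given here, no measured pair shows this same change, so the step from compound 2 to compound 4 in this assay can only be guessed. With compound 2 already standing at 24600 nM, a small movement toward weaker inhibition, or none beyond the scatter, is expected. Compound 4 is thus estimated at 35000 nM, within 9000 nM to 100000 nM, a step of a 1.4-fold higher number from compound 2 to compound 4 (0.15 log units; within the scatter) from compound 2.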

Compound 4, concentration for total growth inhibition: > 100000 nM
Compound 4: a limit, no number; the forecaster's own chance of this, stated with the estimate: 30%; at least 2.8-fold (0.45 log units) between middle value and limit.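

In this assay, going by these compounds alone, the amino group on the aromatic carbon between two ring nitrogen atoms now has a readable step for the first time: hydrogen in its place gives an at least 4.0-fold higher number from compound 2 to compound 4 (0.60 log units; beyond the scatter), so this position is not indifferent to the change. As far as these compounds go, compound 4 gives > 100000 nM, which is a limit and not a number, so the step marks only the smallest possible loss of growth inhibition and its full size stays unknown. That limit is the ceiling of the values shown here: the limit of > 100000 nM in this assay, at which 2 of the 4 values shown sit.

From the compounds shown here alone, whether a methylamino group or a hydroxyl group at this position would hold growth inhibition as the amino group does remains open. Within the data shown here, only this one pair carries the change, so whether it would act alike on a compound with the chloromethyl group placed as in compound 1 is also open.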